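A few compounds are considered here, and "the series" means these few. Any claim that something is new, unique, unknown or untested is made for them only; others in the source may bear on it.

Measured compounds in an in vitro assay on cells for inhibition of Amine oxidase [flavin-containing] A (Homo sapiens), read by Amplex Red, with a stated time of 15 min, tested at 100 uM; a lower number here means less inhibition, a higher number more inhibition at the concentration tested (going by the name of the read-out):

compound 1, `CNC(=S)N1CCC(c2ccc(F)cc2)=N1`: "not active" (no number reported)
compound 2, `CNC(=S)N1CC(C)C(c2ccc(F)cc2)=N1`: "not active" (no number reported)
compound 3, `CC1CN(C(N)=S)N=C1c1ccc(F)cc1`: 40%

Of the compounds shown here, three have been measured. In this assay compound 1 is reported as "not active" (no number reported), and compound 2 is likewise reported as "not active" (no number reported), with no number given for either. Only compound 3 carries a number: in this assay compound 3 gives 40%. Compound 2 therefore stands among the entries without a figure, and nothing in the measured set shows what change in its structure would move it toward the value of compound 3.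

Compound 4, `CNC(=S)N1CC(C)C(c2ccc(OC)cc2)=N1`, is the next compound to be measured. It differs from compound 2 in one place: methoxy in place of fluoro on an aromatic carbon. Among the measured compounds shown here, no step between measured compounds covers a change of this kind, so there is no measured size to lean on. Given that compound 2 is reported as "not active" (no number reported), the step to compound 4 in this assay is expected to be small, probably not beyond the usual scatter, with no direction that can be read from the data.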

Compound 4, a percentage reported as inhibition, at one concentration (the size of the read-out at that concentration, not a potency): "not active" (no number reported)
No number was reported for compound 4, so the estimate cannot be set against anything.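

Compound 2 and compound 4 are both reported without a number in this assay, so no step can be read between them. No further data bear on this result. The compounds shown leave open whether methoxy in place of fluoro changes inhibition at all.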